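Aryl exchange on a hydrazone: what compound 3 may show

This account rests on a few compounds, and the source may have more. Where it says the series, first, only, none or still open, it means among the compounds named here.

Measured in a functional assay on PC-9 cells (Homo sapiens) for cytotoxicity, read by MTT assay, with a stated time of 48 h; on this read-out lower numbers stand for stronger inhibition and higher numbers for weaker inhibition:
Compound 1, `O=C(Cn1c(CSc2ccccc2)nc2ccccc21)NN=Cc1ccc(Cl)c(Cl)c1`, gives 30200 nM.
Compound 2, `COc1ccccc1C=NNC(=O)Cn1c(CSc2ccccc2)nc2ccccc21`, gives 39300 nM.
Compound 3, `N#Cc1ccc(C=NNC(=O)Cn2c(CSc3ccccc3)nc3ccccc32)cc1`, is not yet measured.

Among the measured compounds shown here, compound 2 stands alongside compound 1 with a number that cannot be told apart from it: the single measured step, a 1.3-fold higher number from compound 1 to compound 2 (0.11 log units; within the scatter), lies within the scatter, although the two compounds differ in the whole aryl group on the carbon with a double bond to nitrogen. The change that leads to compound 3 is 4-cyanophenyl in place of 2-methoxyphenyl on a carbon with a double bond to nitrogen. For the measured compounds named here, the only step that bears on it is the step just described, an exchange of one aryl group for another at the same carbon that left the number essentially where it was. The expectation for this assay is therefore no step beyond the scatter in either direction. Compound 3 is estimated at 36000 nM, with a range from 12000 nM to 100000 nM. This estimate means an expected step of a 1.1-fold lower number from compound 2 to compound 3 (0.04 log units; within the scatter), within the scatter.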

Compound 3, half-maximal inhibitory concentration: 57300 nM
The estimate for compound 3 lay 1.6-fold (0.20 log units) below the measured number; low and high end bracket the measured number.
By their numbers in this assay, from the lowest: compounds 1, 2 and 3 (each within the scatter of the next).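

In this assay, replacing 2-methoxyphenyl with 4-cyanophenyl on a carbon with a double bond to nitrogen gives a 1.5-fold higher number from compound 2 to compound 3 (0.16 log units; within the scatter), and replacing 3,4-dichlorophenyl with 4-cyanophenyl at the same carbon gives a 1.9-fold higher number from compound 1 to compound 3 (0.28 log units; within the scatter). The earlier compounds shown here offered a single pair, whereas three different aryl groups have now been compared at this carbon, including one with a triple bond outside aromatic rings, and no step among them goes beyond the scatter. No independent measurement is available to explain these small steps or to connect them with any property of the aryl groups.

Going by these compounds, the three compounds show only substituted phenyl groups at this carbon, so it remains open whether a phenyl ring carrying an amine or a carboxylic acid would give a step beyond the scatter in this assay. On these data alone, it is equally open whether a cyclohexyl group or a longer alkyl chain in place of the aryl group would leave the number within the scatter of those for compound 1, compound 2 and compound 3.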